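The source may hold more compounds than are shown below. What is called first, only, known or untested is meant among the compounds shown, and "the series" means these compounds.

Measured so far in a physicochemical assay for lipophilicity, read by HPLC, at pH 7.5; a higher number here means a more lipophilic compound, a lower number a more polar compound:
- compound 1 `CC[C@@H](Nc1c(C#N)c(-c2ccc(Br)cc2)nc2cnccc12)C(N)=O`: 2.2
- compound 2 `CC[C@@H](Nc1c(C#N)c(-c2ccc(-c3cccc(C)c3F)cc2)nc2cnccc12)C(N)=O`: 3
- compound 3 `CC[C@@H](Nc1c(C#N)c(-c2ccc(-c3ccc(Cl)cc3)cc2)nc2cnccc12)C(N)=O`: 3.1

Compound 3 carries the highest number of the three. Its nearest neighbour is compound 2, and that gap, a number 0.10 log units higher from compound 2 to compound 3 (within the scatter), lies within the scatter, so the two cannot be ordered. Against compound 1 the difference is clear: a number 0.90 log units higher from compound 1 to compound 3 (beyond the scatter), and the related step of a number 0.80 log units higher from compound 1 to compound 2 (beyond the scatter) is of the same size. Within the data shown here, both larger steps come from replacing bromo on an aromatic carbon by a substituted phenyl; the only step that changes the substituent pattern on the distal ring, from compound 2 to compound 3, stays within the scatter.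

Compound 4 `CC[C@@H](Nc1c(C#N)c(-c2ccc(-c3ccc(OC)cc3)cc2)nc2cnccc12)C(N)=O` is not yet measured. The change from compound 3 is methoxy in place of chloro on an aromatic carbon. Among the measured compounds shown here, none of the measured steps exchanges chloro for methoxy, so there is no direct precedent; the one step on the distal ring, compound 2 to compound 3, gave no movement beyond the scatter. Drawing on general experience with such exchanges rather than on these data, a modest decrease is expected, a number 0.60 log units lower from compound 3 to compound 4 (beyond the scatter). Compound 4 is therefore estimated at 2.5, with a range from 2.1 to 2.9.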

Compound 4, distribution coefficient: 2.7
The estimate for compound 4 lay 0.20 log units below the measured number; the range from low to high includes it.
By their numbers in this assay, from the lowest: compound 1; then compounds 4, 2 and 3 (each within the scatter of the next, the first and the last beyond it).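

In this assay, among these compounds, the place para to a large group on the six-membered aromatic ring of carbon only now gives a step beyond the scatter, a number 0.40 log units lower from compound 3 to compound 4 (beyond the scatter), with methoxy in place of chloro; the one earlier change in the outer aryl group, from 2-fluoro-3-methylphenyl to 4-chlorophenyl, stayed within the scatter. So the outer aryl group can register in this read-out, though not for every exchange: a number 0.30 log units lower from compound 2 to compound 4 (within the scatter), which leaves 4-methoxyphenyl and 2-fluoro-3-methylphenyl unordered. Replacing bromo by 4-methoxyphenyl also gives a step beyond the scatter, a number 0.50 log units higher from compound 1 to compound 4 (beyond the scatter), so compound 1 now stands apart from all three compounds carrying a second aryl group.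

The compounds shown come with no independent data that could explain these differences. On these data alone, it remains open what a carboxylic acid, a dimethylamino group or a longer ethoxy chain would give at this same place, and whether the exchange of chloro for methoxy would give a similar step elsewhere on the ring.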